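A few compounds are considered here, and "the series" means these few. Any claim that something is new, unique, unknown or untested is made for them only; others in the source may bear on it.

Measured compounds:
compound 1, `Cc1cc(C)cc(NC(=O)COc2cc(C)nc3ccc(F)cc23)c1`: 5.79
compound 2, `COc1cccc(NC(=O)COc2cc(C)nc3ccc(OC)cc23)c1`: 4.49

In a physicochemical assay for lipophilicity, read by HPLC, in phosphate buffer, measured as chromatographic lipophilicity, at pH 7.4 (a lower number here means a more polar compound, a higher number a more lipophilic compound), compound 2 stands at the lower of the two numbers, with compound 1 higher by a gap beyond the scatter. Compound 3, `COc1ccc2nc(C)cc(OCC(=O)NNC(=O)c3ccncc3)c2c1`, is not yet measured. It differs from compound 2 in one place: ((pyridin-4-yl)carbonyl)amino in place of 3-methoxyphenyl on an amide-type nitrogen. For the measured compounds named here, no step between measured compounds is at hand to set the size of such a change, so the expectation rests on compound 2 alone. Estimated here is a number 1.99 log units lower from compound 2 to compound 3 (beyond the scatter), a downward move beyond the scatter. Compound 3 is expected at 2.5, within 1.8 to 3.3.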

Compound 3, distribution coefficient: 1.48
Beside the measured number, compound 3's estimate is 1.02 log units above it; the whole stated range lies above it.
By their numbers in this assay, from the lowest: compound 3; then compound 2; then compound 1.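

With ((pyridin-4-yl)carbonyl)amino in place of 3-methoxyphenyl on an amide-type nitrogen, this assay shows a number 3.01 log units lower from compound 2 to compound 3 (beyond the scatter) and this large step is the only single-place measure at this position among the compounds shown. It shows that a change at this one place can move the reading far. Nothing at hand says what in the exchanged group accounts for the step. The compounds shown leave open how much of the step belongs to the ring nitrogen and how much to the carbonyl and amino link. A benzoylamino group at the same place would separate the two.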